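One hydroxy group leaves compound 2

A few compounds are considered here, and "the series" means these few. Any claim that something is new, unique, unknown or untested is made for them only; others in the source may bear on it.

- Compound 1 `CC[C@H](C)[C@H]1C(=O)N[C@H](Cc2cc(Cl)c(O)c(Cl)c2)C(=O)N[C@@H](C(C)C)C(=O)O[C@H](c2ccccc2)[C@H](C)/C=C/C=C(\C)[C@H](OC)C[C@@H]2O[C@@]2(C)C(=O)N1C` gives 15.5 nM in the test below
- Compound 2 `CC[C@H](C)[C@H]1C(=O)N[C@H](Cc2ccc(O)c(Br)c2)C(=O)N[C@@H](C(C)(C)O)C(=O)O[C@H](c2ccccc2)[C@H](C)/C=C/C=C(\C)[C@H](OC)C[C@@H]2O[C@@]2(C)C(=O)N1C` gives 9.61 nM in the same test

Both numbers come from a functional assay on PANC-1 cells (Homo sapiens) for antiproliferative activity (a lower number here means a stronger inhibitor, a higher number a weaker inhibitor), and stand close together. Compound 2 lies within the usual scatter of compound 1, so the two cannot be ranked.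

Compound 3 `CC[C@H](C)[C@H]1C(=O)N[C@H](Cc2ccc(O)c(Br)c2)C(=O)N[C@@H](C(C)C)C(=O)O[C@H](c2ccccc2)[C@H](C)/C=C/C=C(\C)[C@H](OC)C[C@@H]2O[C@@]2(C)C(=O)N1C` is compound 2 with one change (hydrogen in place of hydroxy on a saturated chain carbon bound to two saturated chain carbons and a saturated ring carbon): hydrogen in place of hydroxy on a saturated chain carbon bound to two saturated chain carbons and a saturated ring carbon. The 1-hydroxy-1-methylethyl group thereby becomes isopropyl, the group that compound 1 also carries.

Within the data shown here, no measured pair shows this change alone. Compound 1 and compound 2 differ in this group and in one other place, yet compound 2 at 9.61 nM and compound 1 at 15.5 nM remain within the scatter of each other. In this assay no step beyond the scatter is therefore expected, and no clear direction either. The estimated change is a 1.1-fold higher number from compound 2 to compound 3 (0.06 log units; within the scatter) and would be too small to read as real. Compound 3 is estimated at 11 nM with an expected range from 4 nM to 30 nM in this test.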

Compound 3, half-maximal inhibitory concentration: 15.7 nM
The estimate for compound 3 lay 1.4-fold (0.15 log units) below the measured number, and the stated range covers the measured number.
By their numbers in this assay, from the lowest: compounds 2, 1 and 3 (each within the scatter of the next).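

In this assay, the exchange of the 1-hydroxy-1-methylethyl group for isopropyl can now be read on its own, free of any other difference: it gives a 1.6-fold higher number from compound 2 to compound 3 (0.21 log units; within the scatter). At this position on the saturated chain carbon, the hydroxy group can therefore be replaced by hydrogen without a difference that can be told from assay noise. Compound 3 also isolates the other difference, 3-bromo-4-hydroxyphenyl in place of 3,5-dichloro-4-hydroxyphenyl, which gives a 1.0-fold higher number from compound 1 to compound 3 (0.01 log units; within the scatter), so neither single change separates these compounds, and no independent measurement is available to say why.

The compounds shown leave open whether this position accepts groups other than these two, such as an amine or a methoxy group in place of the hydroxy group, or a longer chain such as tert-butyl or n-butyl in place of isopropyl. They also leave open whether the hydroxy group, silent in this assay, makes any difference in a measurement of another kind, since every number here comes from that single test.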